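A Small Change on the Amine Nitrogen

A few compounds are considered here, and "the series" means these few. Any claim that something is new, unique, unknown or untested is made for them only; others in the source may bear on it.

Among the measured compounds shown here, in a functional assay on HT-29 cells (Homo sapiens) for inhibition, read by sulforhodamine B assay, with a stated time of 72 h (a higher number here means a weaker inhibitor, a lower number a stronger inhibitor), compound 1 (`CCC(C)NC(=C\C(=O)/C=C/c1ccc(O)c(OC)c1)/C=C/c1ccc(O)c(OC)c1`) gives 22300 nM, the only true number available so far. Compound 2 (`COc1cc(/C=C/C(=O)/C=C(/C=C/c2ccc(OC(C)=O)c(OC)c2)NCC(C)C)ccc1OC(C)=O`) is reported as > 25000 nM, which is a limit of the assay and not a number. Compound 3 (`COc1cc(/C=C/C(=O)/C=C(/C=C/c2ccc(O)c(OC)c2)NCC(C)C)ccc1O`) keeps the core of compound 1 and has isobutyl in place of sec-butyl on an amine nitrogen. The two compounds have the same atoms, joined differently. For the measured compounds named here, no measured pair shows what this swap does, so the expectation starts from compound 1 at 22300 nM and foresees no change beyond the usual scatter in this assay, in either direction. The expected result is a 1.1-fold lower number from compound 1 to compound 3 (0.05 log units; within the scatter). For compound 3 the estimated value is 20000 nM, with an expected range from 9000 nM to 40000 nM.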

Compound 3, half-maximal inhibitory concentration: 24000 nM
For compound 3 the middle estimate is 1.2-fold (0.08 log units) below the measured one; measured number inside the range.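

Among the compounds shown here, the first measured pair at this amine nitrogen shows that, in this assay, placing isobutyl where sec-butyl stood gives a 1.1-fold higher number from compound 1 to compound 3 (0.03 log units; within the scatter). Rearranging the same atoms within this butyl substituent therefore leaves no readable mark on the result in this assay. Compound 2 is reported only as a limit, and that limit shows how close to the top of the reported range this series lies: the limit of > 25000 nM in this assay, at which 1 of the 3 values shown sits.

As far as these compounds go, what a truly different group on this nitrogen would do remains open, whether a longer chain such as n-octyl, a cyclohexyl ring or a carboxylic acid. With only these two butyl groups compared, it is also unknown whether any substituent at this position can move the number beyond the usual scatter.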